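The source may hold more compounds than are shown below. What is called first, only, known or untested is meant among the compounds shown, and "the series" means these compounds.

In a functional assay on HCT-116 cells (Homo sapiens) for cytotoxicity, read by MTT assay, with a stated time of 48 h, in the presence of a further agent that is not named here (on this read-out higher numbers stand for an effect only at larger amounts of compound and lower numbers for an effect already at smaller amounts), compound 1 `Cc1nn(C)c2nc(NNC(=O)Nc3cc(Cl)nc(Cl)c3)cc(C3CC3)c12` gives 67700 nM. Compound 2 `Cc1nn(C)c2nc(NNC(=O)Nc3cc(Cl)nc(Cl)c3)cc(-c3ccco3)c12`, measured in the same test, gives 69200 nM, so the two numbers lie within the scatter of each other and neither can be ranked above the other. Compound 3 `Cc1nn(C)c2nc(NNC(=O)Nc3cc(Cl)nc(Cl)c3)cc(-c3ccccc3)c12` is still to be measured. It differs from compound 2 by phenyl in place of furan-2-yl on an aromatic carbon, with phenyl in place of furan-2-yl on an aromatic carbon, opposite the ring nitrogen. Within the data shown here, only one measured step bears on this change: a 1.0-fold higher number from compound 1 to compound 2 (0.01 log units; within the scatter), which lies within the scatter and exchanges cyclopropyl for furan-2-yl on that aromatic carbon. With that single step as the guide, no change beyond the scatter is expected in this assay, and the expected step is a 1.1-fold lower number from compound 2 to compound 3 (0.03 log units; within the scatter). For compound 3 the estimated value is 65000 nM, with an expected range from 30000 nM to 130000 nM.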

Compound 3, half-maximal effective concentration: 80000 nM
Compound 3: middle estimate off by 1.2-fold (0.09 log units), on the low side, within the range that was stated.
By their numbers in this assay, from the lowest: compounds 1, 2 and 3 (each within the scatter of the next).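

In this assay, the step from furan-2-yl to phenyl gives a 1.2-fold higher number from compound 2 to compound 3 (0.06 log units; within the scatter), and the step from cyclopropyl to phenyl gives a 1.2-fold higher number from compound 1 to compound 3 (0.07 log units; within the scatter). Compounds 1 and 2 had compared only cyclopropyl with a five-membered aromatic ring, whereas these steps add a six-membered aromatic ring of carbon only, and all three groups on this aromatic carbon, opposite the ring nitrogen, now stand within the scatter of one another. Phenyl, with 0 hydrogen-bond acceptors, therefore cannot be told apart here from furan-2-yl, with 1, and no measurement at hand accounts for this.

The compounds shown leave open whether an amine or a carboxylic acid on this carbon would move the number beyond the scatter. They also leave open whether a change elsewhere on the shared core would do so.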